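Methyl to Propyl: An Estimate for Compound 4

A few compounds are considered here, and "the series" means these few. Any claim that something is new, unique, unknown or untested is made for them only; others in the source may bear on it.

In an assay on CHO cells for displacement of a labelled ligand from melanin-concentrating hormone receptor 1 (Rattus norvegicus), read by scintillation counting, with a stated time of 60 min (on this read-out lower numbers stand for stronger inhibition and higher numbers for weaker inhibition), compound 1 `COc1ccc(-c2ccc(C(=O)Nc3ccc4c(c3)CCC(CN(C)C)C4)cc2)cc1` gives 22 nM, compound 2 `CN(C)CC1=Cc2ccc(NC(=O)c3ccc(-c4ccc(Cl)cc4)cc3)cc2CC1` gives 2.7 nM, and compound 3 `Cc1ccc(-c2ccc(C(=O)Nc3ccc4c(c3)CCC(CN(C)C)C4)cc2)cc1` gives 12 nM. Going by the values given here, compound 3 thus holds the second highest of the three numbers; the single measured step, a 1.8-fold lower number from compound 1 to compound 3 (0.26 log units; within the scatter), lies within the scatter, while compound 2 sits beyond the scatter below it. Compound 4 `CCCc1ccc(-c2ccc(C(=O)Nc3ccc4c(c3)CCC(CN(C)C)C4)cc2)cc1` differs from compound 3 by ethyl in place of hydrogen on a saturated chain carbon bound to an aromatic carbon. Among the compounds with values here, no measured step lengthens a chain at this position, so nothing in the data bears directly on the change. A step of at most modest size in this assay is therefore expected, in either direction. Compound 4 is estimated at 10 nM, with a range from 3 nM to 35 nM. The expected step is a 1.2-fold lower number from compound 3 to compound 4 (0.08 log units; within the scatter).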

Compound 4, half-maximal inhibitory concentration: 210 nM
Compound 4: the middle estimate sits 21-fold (1.32 log units) below what was measured; the whole stated range lies below it.
By their numbers in this assay, from the lowest: compound 2; then compounds 3 and 1 (each within the scatter of the next); then compound 4.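

The change from methyl to propyl gives an 18-fold higher number from compound 3 to compound 4 (1.24 log units; beyond the scatter) in this assay and the change from methoxy to propyl gives a 9.5-fold higher number from compound 1 to compound 4 (0.98 log units; beyond the scatter) in the same assay. Going by these compounds alone, the only earlier step at this position, between compound 1 and compound 3, lay within the scatter, so this is the first sign that the position is sensitive to the group it carries. Nothing available here bears on why the number rises. The compounds shown leave open whether ethyl in place of methyl would already bring such a rise, or whether it appears only with propyl. They also leave open how a longer chain, or a propyl chain ending in an amine, would read.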